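A few compounds are considered here, and "the series" means these few. Any claim that something is new, unique, unknown or untested is made for them only; others in the source may bear on it.

Measured compounds:
- Compound 1 `CCC1CCN(c2nc(C(C)(C)C)ccc2CNC(=O)C(C)c2ccc(NS(C)(=O)=O)c(F)c2)CC1`: 0.1 nM
- Compound 2 `CC(C(=O)NCc1ccc(C(C)(C)C)nc1N1CCC(Cc2ccccc2)CC1)c1ccc(NS(C)(=O)=O)c(F)c1`: 0.3 nM
- Compound 3 `CCCCOc1nc(C(C)(C)C)ccc1CNC(=O)C(C)c1ccc(NS(C)(=O)=O)c(F)c1`: 0.9 nM

In an assay on cells for antagonist activity at transient receptor potential cation channel subfamily V member 1 (Homo sapiens), read by FLIPR and calcium flux, with a stated time of 6 min (on this read-out lower numbers stand for stronger inhibition and higher numbers for weaker inhibition), compound 3 gives the highest number of the three: from compound 1 the step is a 9.0-fold higher number from compound 1 to compound 3 (0.95 log units; beyond the scatter), and compound 2 sits in between. The other change seen so far, a 3.0-fold higher number from compound 1 to compound 2 (0.48 log units; beyond the scatter), touches a different part of the molecule. Compound 4 `CCOCCOc1nc(C(C)(C)C)ccc1CNC(=O)C(C)c1ccc(NS(C)(=O)=O)c(F)c1` differs from compound 3 by ethoxy in place of ethyl on a saturated chain carbon, two bonds along the chain from an oxygen on an aromatic ring. For the measured compounds named here, no measured pair shows this kind of change at this place, so the two earlier steps only set the scale of what such edits have done here. With nothing closer to lean on, compound 4 is estimated to sit near compound 3, with the step of a 1.7-fold higher number from compound 3 to compound 4 (0.22 log units; within the scatter) expected to stay within the scatter. The expected value for compound 4 is 1.5 nM, with a range from 0.4 nM to 6 nM.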

Compound 4, inhibition constant: 23.9 nM
Compound 4: middle estimate off by 16-fold (1.20 log units), on the low side; the whole stated range lies below it.
By their numbers in this assay, from the lowest: compound 1; then compound 2; then compound 3; then compound 4.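

In this assay, ethoxy in place of ethyl, two bonds along the chain from the oxygen on the aromatic ring, gives a 27-fold higher number from compound 3 to compound 4 (1.42 log units; beyond the scatter), so this chain is far from indifferent to such a change. Against the 4-ethylpiperidin-1-yl group, 2-ethoxyethoxy gives a 240-fold higher number from compound 1 to compound 4 (2.38 log units; beyond the scatter), the widest step among these compounds. Nothing available here accounts for this loss of strength. From the compounds shown here alone, it remains open whether an amine at this place, or a longer all-carbon chain such as hexyloxy, would fare as poorly.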